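Swapping the thiazole for an isothiazole on the shared core

A few compounds are considered here, and "the series" means these few. Any claim that something is new, unique, unknown or untested is made for them only; others in the source may bear on it.

Compound 1 `c1ccc(-c2cc[nH]n2)c(OCC2=NCCN2)c1` gives in a functional assay for activation of Alpha-1B adrenergic receptor (Homo sapiens), read by calcium flux (on this read-out higher numbers stand for an effect only at larger amounts of compound and lower numbers for an effect already at smaller amounts), a value of 79.4 nM. Compound 2 `Cc1ccc(-c2ccccc2OCC2=NCCN2)s1` gives in this assay only a limit, < 100000 nM. Compound 3 `Cc1csc(-c2ccccc2OCC2=NCCN2)n1` likewise gives in this assay only a limit, < 100000 nM.

Compound 3 therefore stands at a limit of the assay, not at a number, and so does compound 2; only compound 1 has a readable value. The new compound 4 `Cc1cc(-c2ccccc2OCC2=NCCN2)sn1` differs from compound 3 in one place: 3-methyl-1,2-thiazol-5-yl in place of 4-methyl-1,3-thiazol-2-yl on an aromatic carbon. The two steps leading to compound 3 are the ones that bear on this change, and both are unreadable: a step that the limit leaves unreadable from compound 1 to compound 3 and a step that the two limits leave unreadable from compound 2 to compound 3, the reason being (the limit of < 100000 nM in this assay, at which 2 of the 3 values shown sit). For the measured compounds named here, no measured step therefore tells how large or in which direction a change at this position moves this assay. Compound 4 is expected to stay near the limit, with an estimated 50000 nM (range 2000 nM to 100000 nM). The expected step is a step that the limit leaves unreadable from compound 3 to compound 4.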

Compound 4, half-maximal effective concentration: < 100000 nM
Compound 4 ended at the assay's limit; the forecaster's own chance of this, stated with the estimate: 70%; the middle value is on the limit's open side.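

Compound 4, like compound 2 and compound 3, gives only a limit in this assay, so its steps to these two and to compound 1 cannot be read, because of this: the limit of < 100000 nM in this assay, at which 3 of the 4 values shown sit.

The compounds shown leave open whether compound 2, compound 3 and compound 4 differ from one another at all, and how far each lies from compound 1.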